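This account rests on a few compounds, and the source may have more. Where it says the series, first, only, none or still open, it means among the compounds named here.

Compound 1 `Cc1ccc2c(Oc3ccccc3OCCn3ccc(=O)[nH]c3=O)cccc2c1` and compound 2 `O=c1ccn(CCOc2ccccc2Oc2cccc3cc(Cl)ccc23)c(=O)[nH]1` share one core and differ in a single place. In an ADME assay on MT2 cells (Homo sapiens) for cytotoxicity, read by MTT assay (on this read-out higher numbers stand for lower toxicity in this test and lower numbers for higher toxicity in this test), compound 1 gives 40000 nM. Compound 2 reaches only a limit of the test, > 100000 nM. The step between them is an at least 2.5-fold higher number from compound 1 to compound 2 (0.39 log units; beyond the scatter), and it can be stated only as a lower bound because of the limit of > 100000 nM in this assay, at which 1 of the 2 values shown sits. Compound 3 `O=c1ccn(CCOc2ccccc2Oc2cc(Cl)cc3cc(Cl)ccc23)c(=O)[nH]1` is not yet measured; it differs from compound 2 by chloro in place of hydrogen on an aromatic carbon. Among the compounds with values here, the only measured step that bears on this change is the one from compound 1 to compound 2, which also brought in a chloro group and ended at the limit of the test. The expected step is therefore a number no higher from compound 2 to compound 3 (the limit leaves the size open), that is, none beyond the scatter, with the reading most likely again at the limit. Compound 3 is estimated at 100000 nM, within a range from 40000 nM to 250000 nM.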

Compound 3, half-maximal cytotoxic concentration: 45000 nM
The estimate for compound 3 lay 2.2-fold (0.35 log units) above the measured number; the range from low to high includes it.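

In this assay, chloro in place of hydrogen on an aromatic carbon, meta to a large group and para to a fused ring, gives an at least 2.2-fold lower number from compound 2 to compound 3 (0.34 log units; beyond the scatter), a shift toward higher toxicity in this test. The earlier step showed only a chloro group replacing methyl at another place, with the number moving upward, so the direction seen with a chloro group now differs between the two changes shown. The value of compound 2 is a limit and not a number, and the new step has only a lower bound: the limit of > 100000 nM in this assay, at which 1 of the 3 values shown sits.

The compounds shown leave open whether fluoro, a methoxy group or an amine at this position would lower the number as well. They also leave open whether chloro here has the same effect when the other chloro group is absent.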